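From methoxy to ethoxycarbonyl in an antiproliferative series

The compounds below may be only part of what the source reports. "The series", "measured", "known", "first", "only" and "open" are said of these compounds alone.

In a functional assay on Huh-7 cells (Homo sapiens) for antiproliferative activity, with a stated time of 48 h (on this read-out higher numbers stand for weaker inhibition and lower numbers for stronger inhibition), compound 1 `CCN(CC)c1ccc(-c2cccc(OC)c2)nn1` reaches only a limit, with > 25000 nM as its entry and not a number. Two neighbours do give numbers. In this assay compound 2 `COC(=O)c1cccc(-c2ccc(-n3cccc3)nn2)c1` gives 30000 nM as its result, and compound 3 `CCOC(=O)c1ccc(-c2ccc(N(CC)CC)nn2)cc1` gives 9000 nM as its result, so the lower number and the stronger inhibition belong to compound 3.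

Compound 4 `CCOC(=O)c1cccc(-c2ccc(N(CC)CC)nn2)c1` has not yet been measured. It departs from compound 1 at one place, (ethoxycarbonyl in place of methoxy on an aromatic carbon), with ethoxycarbonyl in place of methoxy on an aromatic carbon, meta to a large group. No measured step connects any of these compounds, so the size of this change can only be expected. In this assay a modest gain is expected, estimated as an at least 1.6-fold lower number from compound 1 to compound 4 (0.22 log units; that floor lies within the scatter) and pointing toward stronger inhibition. Among the compounds with values here, that expectation leans on compound 3 at 9000 nM as the lowest number so far, and on compound 2 at 30000 nM as the reminder that numbers this weak also occur. A limit remains possible for the new compound. For compound 4 the estimated value is 15000 nM with an expected range from 6000 nM to 35000 nM in this measurement.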

Compound 4, half-maximal inhibitory concentration: > 25000 nM
Compound 4 ended at the assay's limit; the forecaster's own chance of this, stated with the estimate: 25%; middle value at least 1.6-fold (0.22 log units) away from the limit.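

Within the data shown here, compound 1 and compound 4 both end at a limit of the assay and not at a number, so no step between them can be read, and the two share only this entry: the limit of > 25000 nM in this assay, at which 2 of the 4 values shown sit. The compounds shown leave open what ethoxycarbonyl in place of methoxy on an aromatic carbon changes in this assay, in size or in direction.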